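Demethylation of compound 1: methoxy to hydroxy on the aryl ring

The source may hold more compounds than are shown below. What is called first, only, known or untested is meant among the compounds shown, and "the series" means these compounds.

Compound 1 `COc1ccc(C2=C(c3cc(OC)c(OC)c(OC)c3)C(=O)CC2O[SiH2]C(C)(C)C)cc1OC` stands at the limit of an ADME assay on KB cells (Homo sapiens) for cytotoxicity, read by MTT assay, with a stated time of 72 h; a lower number here means a stronger inhibitor, a higher number a weaker inhibitor: in this assay compound 1 gives > 100 ug/mL, a limit of the assay rather than a number. Compound 2 `COc1ccc(C2=C(c3cc(OC)c(OC)c(OC)c3)CC(O)C2=O)cc1[N+](=O)[O-]` likewise returns only a limit, > 100 ug/mL, in this assay. Compound 3 `C=CCOc1cc(C2=C(c3cc(OC)c(OC)c(OC)c3)C(=O)C(O)C2)ccc1OC` also returns a limit, > 100 ug/mL, in this assay. So far nothing is known beyond (the limit of > 100 ug/mL in this assay, at which 3 of the 3 values shown sit), no measured pair differs in one place, and no step can be sized.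

Compound 4 `COc1ccc(C2=C(c3cc(OC)c(OC)c(OC)c3)C(=O)CC2O[SiH2]C(C)(C)C)cc1O` differs from compound 1 by hydrogen in place of methyl on an oxygen on an aromatic ring. With every value shown sitting at the limit, no step beyond the scatter is expected in this assay. The expected step from compound 1 to compound 4 is a number no higher from compound 1 to compound 4 (the limit leaves the size open). Compound 4 is therefore estimated at 100 ug/mL in this assay, most likely again only a limit, with a range from 25 ug/mL to 300 ug/mL.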

Compound 4, half-maximal inhibitory concentration: 6.5 ug/mL
Compound 4: middle estimate off by 15-fold (1.19 log units), on the high side; measured number outside the range, below it.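

In this assay, hydrogen in place of methyl on an oxygen on an aromatic ring gives an at least 15-fold lower number from compound 1 to compound 4 (1.18 log units; beyond the scatter). Compound 4 is thus the first compound shown to give a number rather than a limit, so this one position on the 3,4-dimethoxyphenyl ring can move the read-out. The true size of the step stays unknown, as the starting value is only a limit: the limit of > 100 ug/mL in this assay, at which 3 of the 4 values shown sit.

As far as these compounds go, whether an amine or a carboxylic acid in place of the hydroxy would keep a number of this order remains open. So does whether methoxy to hydroxy acts alike at other places on the shared core.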